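Swapping an aromatic group for cyclopropyl

A few compounds are considered here, and "the series" means these few. Any claim that something is new, unique, unknown or untested is made for them only; others in the source may bear on it.

In an ADME assay on MDCK cells (Canis lupus familiaris) for cytotoxicity, read by MTT assay, with a stated time of 48 h (a higher number here means that more compound is tolerated, a lower number that less compound is tolerated), compound 1 `FC(F)(F)Oc1ccc(-c2cn(CC3=C(Cl)c4ccc(-c5cccs5)nc4CC3)nn2)cc1` gives > 300 ug/mL as its reading, which is a limit of the assay and not a number. So compound 1 stands at the limit of > 300 ug/mL in this assay, at which 1 of the 2 values shown sits, with no exact rank. Compound 2 `FC(F)(F)c1cc(-c2cn(CC3=C(Cl)c4ccc(-c5cccs5)nc4CC3)nn2)cc(C(F)(F)F)c1`, which has the shared core with a different group, gives 35 ug/mL as a measured number.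

Compound 3 `ClC1=C(Cn2cc(C3CC3)nn2)CCc2nc(-c3cccs3)ccc21` has cyclopropyl in place of 4-(trifluoromethoxy)phenyl on an aromatic carbon of a five-membered aromatic ring with 3 nitrogen. For the measured compounds named here, no measured step shows what this swap does. Compound 2 at 35 ug/mL shows that a measurable reading can occur on this core, so a moderate fall is expected rather than none. The expected change is an at least 2.5-fold lower number from compound 1 to compound 3 (0.39 log units; beyond the scatter) in this assay and it is only an estimate. For compound 3 the estimated value is 120 ug/mL with an expected range from 30 ug/mL to 300 ug/mL for this reading.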

Compound 3, half-maximal cytotoxic concentration: > 300 ug/mL
Compound 3: a limit, no number; the forecaster's own chance of this, stated with the estimate: 35%; middle value at least 2.5-fold (0.39 log units) away from the limit.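

In this assay, for the compounds shown here, compound 1 and compound 3 both give a limit of the assay and not a number, so the swap to cyclopropyl yields no step that can be read: the limit of > 300 ug/mL in this assay, at which 2 of the 3 values shown sit.

Going by these compounds, the exact readings of compound 1 and compound 3, and so the effect of this swap, stay open.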